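Octadecyl amides: furan to thiophene on the acyl group

The source may report more compounds than this note shows. Statements on the series, on what has been measured and on what is new or still open speak of the compounds shown alone.

Values in a functional assay on SW-620 cells (Homo sapiens) for cytotoxicity, read by MTT assay, with a stated time of 48 h (a lower number here means a stronger inhibitor, a higher number a weaker inhibitor), for the measured compounds:
compound 1, `CCCCCCCCNC(=O)[C@@H](NC(=O)c1cccs1)[C@@H](C)O`: 136000 nM
compound 2, `CCCCCCCCCCCCCCNC(=O)[C@@H](NC(=O)c1cccs1)[C@@H](C)O`: 78400 nM
compound 3, `CCCCCCCCCCCCCCCCCCNC(=O)[C@@H](NC(=O)c1ccco1)[C@@H](C)O`: > 200000 nM

In this assay compound 3 gives only a limit, > 200000 nM, so no number fixes its place among the measured values. Compound 3 stands at the limit of > 200000 nM in this assay, at which 1 of the 3 values shown sits. Compound 4, `CCCCCCCCCCCCCCCCCCNC(=O)[C@@H](NC(=O)c1cccs1)[C@@H](C)O`, differs from compound 3 by thiophen-2-yl in place of furan-2-yl on a carbonyl carbon. Going by the values given here, no measured step covers this exchange; the only measured step, a 1.7-fold lower number from compound 1 to compound 2 (0.24 log units; within the scatter), concerns chain length and stays within the scatter. Compounds 1 and 2 already carry the thiophene, and both return numbers. The step of an at least 2.0-fold lower number from compound 3 to compound 4 (0.30 log units; that floor lies within the scatter) is therefore expected to be small, its direction set only by the limit of compound 3. Compound 4 is expected near 100000 nM, with a range from 40000 nM to 250000 nM.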

Compound 4, half-maximal inhibitory concentration: 200000 nM
The estimate for compound 4 lay 2.0-fold (0.30 log units) below the measured number; the measured number falls inside the stated range.
By their numbers in this assay, from the lowest: compounds 2, 1 and 4 (each within the scatter of the next, the first and the last beyond it).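

Going by these compounds alone, with the thiophen-2-yl acyl group held fixed, the longest chain gives the first step beyond the scatter in this assay, though a modest one: a 2.6-fold higher number from compound 2 to compound 4 (0.41 log units; beyond the scatter). The other chain step stays within the scatter, a 1.5-fold higher number from compound 1 to compound 4 (0.17 log units; within the scatter), so lengthening the chain gives no steady fall in the number, and compound 4 goes against one. Thiophen-2-yl in place of furan-2-yl on a carbonyl carbon gives a number no higher from compound 3 to compound 4 (the limit leaves the size open). The size of this step cannot be read, because compound 3 gives only a limit: the limit of > 200000 nM in this assay, at which 1 of the 4 values shown sits.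

On these data alone, whether furan-2-yl on a shorter chain returns a number stays open. So does the effect of an amine or a carboxylic acid at the chain end.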